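Swapping tert-butyl for chloro on the benzyl group

The source may report more compounds than this note shows. Statements on the series, on what has been measured and on what is new or still open speak of the compounds shown alone.

Compound 1 (`CCN(CC)Cc1ccc2nc(NC(=O)N/N=C/c3cn(Cc4ccc(C(C)(C)C)cc4)c4ccccc34)sc2c1`) gives 1670 nM 
Compound 2 (`CN(C)Cc1ccc2nc(NC(=O)N/N=C/c3cn(Cc4ccc(C(C)(C)C)cc4)c4ccccc34)sc2c1`) gives 810 nM 
Compound 3 (`CC1CCN(Cc2ccc3nc(NC(=O)N/N=C4\C(=O)Nc5ccc(F)cc54)sc3c2)CC1`) gives 1430 nM 

In a functional assay on NCI-H460 cells (Homo sapiens) for cytotoxicity, read by MTT assay, with a stated time of 72 h (on this read-out lower numbers stand for stronger inhibition and higher numbers for weaker inhibition), compound 1 gives 1670 nM and sits within the scatter of compound 3, while compound 2 lies beyond the scatter, with a 2.1-fold lower number from compound 1 to compound 2 (0.31 log units; beyond the scatter) as the measured step.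

The next compound, compound 4 (`CCN(CC)Cc1ccc2nc(NC(=O)N/N=C/c3cn(Cc4ccc(Cl)cc4)c4ccccc34)sc2c1`), keeps the core of compound 1 and its diethylamino group. The change is chloro in place of tert-butyl on an aromatic carbon, which turns 4-(tert-butyl)benzyl into 4-chlorobenzyl.

Among the compounds with values here, no measured step touches this group. The only one, a 2.1-fold lower number from compound 1 to compound 2 (0.31 log units; beyond the scatter), replaces diethylamino with dimethylamino and keeps tert-butyl, so it offers a sense of scale but no direction. Compound 3 differs from compound 1 in several places and isolates nothing.

A small change of open direction is therefore expected, with a 1.4-fold lower number from compound 1 to compound 4 (0.14 log units; within the scatter) as the estimated step. The estimate for compound 4 is 1200 nM as the expected value, with 400 nM to 3500 nM as its expected range.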

Compound 4, half-maximal inhibitory concentration: 370 nM
Compound 4: the middle estimate sits 3.2-fold (0.51 log units) above what was measured; measured number outside the range, below it.
By their numbers in this assay, from the lowest: compound 4; then compounds 2, 3 and 1 (each within the scatter of the next, the first and the last beyond it).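

With the diethylamino group held fixed, the group on the benzyl ring turns out to matter in this assay: chloro in place of tert-butyl gives a 4.5-fold lower number from compound 1 to compound 4 (0.65 log units; beyond the scatter). Within the data shown here, this gives the position its first direction, since the only earlier step changed the amine and left tert-butyl in place. Nothing available explains this shift.

Going by these compounds, what fluoro, methoxy or a plain hydrogen would do at this place remains open, so it cannot be told whether the step follows the loss of tert-butyl or the arrival of chloro. On these data alone, it is also open whether 4-chlorobenzyl would give a step of similar size on the dimethylamino compound 2, or whether the two changes would simply add.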